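Swapping a Small Ring for Furan on a Shared Scaffold

This account rests on a few compounds, and the source may have more. Where it says the series, first, only, none or still open, it means among the compounds named here.

Of the compounds shown here, three have been measured in a functional assay on the whole organism (plasma, strain Sprague-Dawley) with Rattus norvegicus as the target, with a stated time of 2 h, at a dose of 100 mg/kg by the oral route; on this read-out higher numbers stand for a stronger effect at the one dose given and lower numbers for a weaker effect. Compound 1 `c1ccc(C(/N=C2\CCCCN2)C2CC2)cc1` and compound 2 `c1ccc(C(/N=C2\CCCCCCN2)C2CC2)cc1` share much of their framework, but the difference between the two cores is not broken down here; in this assay compound 1 gives 36% and compound 2 gives 58%, the highest of the three measured numbers. Compound 3 `c1ccc(C(/N=C2\CCCCN2)c2ccco2)cc1` is compound 1 with one change, (furan-2-yl in place of cyclopropyl on a saturated chain carbon bound to an aromatic carbon and a double-bonded nitrogen). In this assay compound 3 gives 27%. The step that this change made, a number 9 percentage points lower from compound 1 to compound 3 (within the scatter), is small enough to count as noise.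

Compound 4 `c1ccc(C(/N=C2\CCCCCCN2)c2ccco2)cc1` is built from compound 2 by the same change, (furan-2-yl in place of cyclopropyl on a saturated chain carbon bound to an aromatic carbon and a double-bonded nitrogen), at a place described in the same words as before. For the measured compounds named here, the earlier step is the only guide for how the change behaves, so the expected step is similar: compound 4 is estimated to move by a number 9 percentage points lower from compound 2 to compound 4 (within the scatter) in this assay. Going by the values given here, compound 4 is therefore expected to give about 49% in this assay, with a likely range from 32% to 66%, because the one measured example of this change, a number 9 percentage points lower from compound 1 to compound 3 (within the scatter), stayed within the scatter.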

Compound 4, a percentage reported as inhibition, in the whole organism at one dose (the size of the read-out at that dose, not a potency): 61%
The estimate for compound 4 lay 12 percentage points below the measured number, and the stated range covers the measured number.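

In this assay, putting furan-2-yl in place of cyclopropyl on the core of compound 2 gives a number 3 percentage points higher from compound 2 to compound 4 (within the scatter). Set beside the earlier case, the change behaves alike on the two cores as far as this read-out can tell: the same change on two cores in this assay, a number 9 percentage points lower (within the scatter) from compound 1 to compound 3 and a number 3 percentage points higher (within the scatter) from compound 2 to compound 4, 12 percentage points apart, within the scatter of two such steps In these two pairs, then, the swap leaves no effect that can be told from the scatter, and the core it sits on makes no visible difference to it, but two pairs at a single dose cannot show that the same would hold on a third core, or that the two groups are interchangeable at other doses or in other read-outs.

The compounds shown leave open what other groups would do at the same place, on a saturated chain carbon bound to an aromatic carbon and a double-bonded nitrogen. A small chain such as methyl, a thiophene ring or an amine there could each be tested on both cores, to see whether the two cores still respond alike.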